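Tert-butoxy for tert-butyl: working notes on the series

The compounds below may be only part of what the source reports. "The series", "measured", "known", "first", "only" and "open" are said of these compounds alone.

Measured in a functional assay on a cell-free system (plasma, Homo sapiens), with a stated time of 3 min; on this read-out lower numbers stand for stronger inhibition and higher numbers for weaker inhibition:
- compound 1 `CCCC[C@@H](O)C(=O)N1C[C@H]2C[C@H]2[C@H]1C(=O)NCc1cc(Cl)ccc1-n1cnnn1`: 750 nM
- compound 2 `CC(C)(C)C[C@@H](O)C(=O)N1C[C@@H]2C[C@@H]2[C@H]1C(=O)NCc1cc(Cl)ccc1-n1cnnn1`: 910 nM

Compound 2, at 910 nM, stands level with compound 1 at 750 nM, and the gap lies within the scatter. Within the data shown here, these two compounds differ in more than one place, so no single-change step is available from the measured pair.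

Compound 3 `CC(C)(C)OC[C@@H](O)C(=O)N1C[C@@H]2C[C@@H]2[C@H]1C(=O)NCc1cc(Cl)ccc1-n1cnnn1` carries tert-butoxy in place of tert-butyl on a saturated chain carbon, two bonds along the chain from a carbonyl carbon and an oxygen on a saturated carbon. Among the measured compounds shown here, no measured compound shows this change on its own. In this assay no step beyond the scatter is expected, and neither direction is favoured. The expected step of a 1.1-fold lower number from compound 2 to compound 3 (0.03 log units; within the scatter) is therefore small. Two measured compounds are a thin basis, so the expected range is kept wide. For compound 3 the estimated value is 850 nM, with an expected range of 280 nM to 2600 nM.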

Compound 3, half-maximal inhibitory concentration: 570 nM
The estimate for compound 3 lay 1.5-fold (0.17 log units) above the measured number; low and high end bracket the measured number.
By their numbers in this assay, from the lowest: compounds 3, 1 and 2 (each within the scatter of the next).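

In this assay tert-butoxy in place of tert-butyl on a saturated chain carbon, two bonds along the chain from a carbonyl carbon and an oxygen on a saturated carbon, gives a 1.6-fold lower number from compound 2 to compound 3 (0.20 log units; within the scatter) and is the only single-change step among the compounds shown. This position therefore accepts one more heavy atom, an oxygen that adds a hydrogen-bond acceptor by count, without a step beyond the scatter. Nothing shown explains the size of this step.

Compound 1 differs from compound 3 in more than one place, so its chain cannot be set against tert-butoxy as a single change. From the compounds shown here alone, whether this position would also accept an amine, a carboxylic acid or a longer chain remains open, as does whether tert-butoxy would give a similar step on the core of compound 1.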